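Compound 3: 1-carboxyethyl in place of 2-carboxyethyl

The source may report more compounds than this note shows. Statements on the series, on what has been measured and on what is new or still open speak of the compounds shown alone.

Among the measured compounds shown here, in a functional assay on DU-145 cells (Homo sapiens) for cytotoxicity, read by trypan blue exclusion, with a stated time of 96 h (on this read-out lower numbers stand for stronger inhibition and higher numbers for weaker inhibition), compound 2 (`COc1cc(OC)c(/C=C/S(=O)(=O)Cc2ccc(OC)c(NCCC(=O)O)c2)c(OC)c1`) gives 5000 nM and holds the higher of the two numbers so far. Compound 1 (`COC(=O)[C@H](C)Nc1cc(CS(=O)(=O)/C=C/c2c(OC)cc(OC)cc2OC)ccc1OC`) stands lower with 750 nM there.

Compound 3 (`COc1cc(OC)c(/C=C/S(=O)(=O)Cc2ccc(OC)c(N[C@@H](C)C(=O)O)c2)c(OC)c1`) has 1-carboxyethyl in place of the 2-carboxyethyl of compound 2 on a nitrogen on an aromatic ring (1-carboxyethyl in place of 2-carboxyethyl on a nitrogen on an aromatic ring). For the measured compounds named here, the one measured step bearing on this is a 6.7-fold higher number from compound 1 to compound 2 (0.82 log units; beyond the scatter) and it came with 2-carboxyethyl replacing 1-(methoxycarbonyl)ethyl. That modest step joins two changes, and the data do not separate them. Compound 3 keeps the carboxyl of compound 2 but attaches its chain as compound 1 does, so only part of that step is expected to return. This expectation amounts to an estimated 3.3-fold lower number from compound 2 to compound 3 (0.52 log units; beyond the scatter) in the direction of a lower number. For compound 3 the estimated value is 1500 nM (range 350 nM to 6000 nM).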

Compound 3, half-maximal inhibitory concentration: 25 nM
Compound 3: middle estimate off by 60-fold (1.78 log units), on the high side; measured number outside the range, below it.
By their numbers in this assay, from the lowest: compound 3; then compound 1; then compound 2.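

In this assay, the same atoms joined as 1-carboxyethyl rather than 2-carboxyethyl on the nitrogen on an aromatic ring give a 200-fold lower number from compound 2 to compound 3 (2.30 log units; beyond the scatter), which shows that the way the chain is joined at this position can carry a large change on its own. The carboxyl does not by itself go with a high number: hydrogen in place of methyl on an oxygen next to a carbonyl group gives a 30-fold lower number from compound 1 to compound 3 (1.48 log units; beyond the scatter), so the free acid, not the methyl ester, holds the lowest number of the three here. Nothing available explains why either change has this effect.

The compounds shown leave open whether the opposite configuration at the defined stereocentre of 1-carboxyethyl would keep this number. They also leave open whether a 1-carboxypropyl chain, or a primary amide in place of the carboxylic acid, would keep it.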